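Cytotoxicity notes: amide aryl change from compound 3 to 4

This account rests on a few compounds, and the source may have more. Where it says the series, first, only, none or still open, it means among the compounds named here.

The series shares one core and differs only in the aryl group on the amide-type nitrogen. Tolerance was read in an ADME assay on LLC-MK2 cells (Macaca mulatta) for cytotoxicity, read by spectrophotometry and crystal violet staining, with a stated time of 4 days; a higher number here means that more compound is tolerated, a lower number that less compound is tolerated. Compound 1 `CC(C)n1ncc2c(C(=O)Nc3cccc(F)c3)cc(-c3cccs3)nc21` returns only a limit of this assay, > 200000 nM. Compound 2 `CC(C)n1ncc2c(C(=O)Nc3c(F)cccc3F)cc(-c3cccs3)nc21` likewise returns only a limit, > 200000 nM. Going by the values given here, compound 3 `CC(C)n1ncc2c(C(=O)Nc3ccccc3F)cc(-c3cccs3)nc21` is the one member with a number, giving 50000 nM, so it stands as the least tolerated of the three, with the two others sitting at the limit of > 200000 nM in this assay, at which 2 of the 3 values shown sit.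

The readable steps are an at least 4.0-fold lower number from compound 1 to compound 3 (0.60 log units; beyond the scatter) and an at least 4.0-fold lower number from compound 2 to compound 3 (0.60 log units; beyond the scatter); the step that the two limits leave unreadable from compound 1 to compound 2 cannot be sized. Both readable steps move fluorine about the phenyl ring and both lower tolerance toward compound 3.

Compound 4 `CC(C)n1ncc2c(C(=O)Nc3ccc(F)cn3)cc(-c3cccs3)nc21` carries 5-fluoropyridin-2-yl in place of 2-fluorophenyl on an amide-type nitrogen. Among the compounds with values here, no measured step exchanges the carbon ring for a ring with one hetero atom, so the measured steps bear only indirectly: they show that the aryl group on the amide-type nitrogen can shift tolerance by at least a modest amount in either direction. With compound 3 at the low end of the set, a change back toward the tolerance seen in compound 1 and compound 2 is expected rather than a further fall, with a step of a 1.6-fold higher number from compound 3 to compound 4 (0.20 log units; within the scatter) expected. For compound 4 the estimated value in this assay is 80000 nM, within 25000 nM to 200000 nM.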

Compound 4, half-maximal cytotoxic concentration: > 200000 nM
Compound 4: a limit, no number (the forecaster's own chance of this, stated with the estimate: 35%); middle value at least 2.5-fold (0.39 log units) away from the limit.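

In this assay, 5-fluoropyridin-2-yl in place of 2-fluorophenyl on the amide-type nitrogen gives an at least 4.0-fold higher number from compound 3 to compound 4 (0.60 log units; beyond the scatter), the first sign that this position accepts an aromatic ring with one hetero atom without the lower tolerance seen for compound 3. The value of compound 4, > 200000 nM, is a limit of the assay and not a number. Going by these compounds alone, compound 3 therefore remains the only member of the series with a number, while all the other aryl groups on the amide-type nitrogen share one ceiling: the limit of > 200000 nM in this assay, at which 3 of the 4 values shown sit.

The steps from compound 1 and from compound 2 to compound 4 cannot be read, so these three compounds cannot be placed in any order, and the ceiling gives no way of telling whether the pyridine ring differs in tolerance from the 3-fluorophenyl or 2,6-difluorophenyl groups. Also open, going by these compounds, is how this assay would read for pyridin-2-yl without the fluorine, or for an aryl group carrying an amine or a carboxylic acid at the same place on the amide-type nitrogen.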